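The source may report more compounds than this note shows. Statements on the series, on what has been measured and on what is new or still open speak of the compounds shown alone.

Working notes on the series. Among the measured compounds shown here, compound 3 `CCC1CCCCN1C[C@@H](O)CNS(=O)(=O)c1cccc2ccccc12` stands at the higher end of the two single numbers so far in an assay on HEK293 cells for inhibition of sodium- and chloride-dependent glycine transporter 1 (Homo sapiens); a lower number here means a stronger inhibitor, a higher number a weaker inhibitor: compound 3 gives 7940 nM, while compound 2 `CCC1CCC(C)N(C[C@@H](O)CNS(=O)(=O)c2cccc3ccccc23)C1` gives 1000 nM, a step of a 7.9-fold higher number from compound 2 to compound 3 (0.90 log units; beyond the scatter). Compound 1 `O=S(=O)(NC[C@H](O)CN1CCCC1C1CCCCC1)c1cccc2ccccc12` gives 6310 nM; 6310 nM (2 entries) in two entries, a number that sits within the scatter of compound 3. Compound 4 `O=S(=O)(NC[C@H](O)CN1CCCC1)c1cccc2ccccc12` is the next member, and its change from compound 3 is pyrrolidin-1-yl in place of 2-ethylpiperidin-1-yl on a saturated chain carbon, two bonds along the chain from an oxygen on a saturated carbon. For the measured compounds named here, no measured step shares this change: the one step available swaps one substituted piperidine for another, so it gives no direct guide. Compound 1, which also carries a five-membered ring at this place, does not separate from compound 3 beyond the scatter. Compound 4 is therefore expected to lie close to compound 3 or somewhat weaker, a step of a 1.9-fold higher number from compound 3 to compound 4 (0.28 log units; within the scatter), estimated at 15000 nM with a range of 5000 nM to 50000 nM.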

Compound 4, half-maximal inhibitory concentration: 3160 nM
Compound 4: middle estimate off by 4.7-fold (0.68 log units), on the high side; measured number outside the range, below it.
By their numbers in this assay, from the lowest: compound 2; then compound 4; then compound 3.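

In this assay the smaller pyrrolidin-1-yl group is tolerated at this place on the saturated chain carbon and improves on 2-ethylpiperidin-1-yl (a 2.5-fold lower number from compound 3 to compound 4 (0.40 log units; beyond the scatter)), yet it falls short of 5-ethyl-2-methylpiperidin-1-yl (a 3.2-fold higher number from compound 2 to compound 4 (0.50 log units; beyond the scatter)). The number therefore does not follow the size of the group in one direction across these three compounds: compound 4, with the smallest group, lies between compound 2 and compound 3. Nothing measured on hand accounts for this order.

Open, as far as these compounds go, is where a piperidin-1-yl without an ethyl or methyl group, or a morpholin-4-yl, would fall at this place.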